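Permeability of Two Related Cores and a Fluorine Removal

A few compounds are considered here, and "the series" means these few. Any claim that something is new, unique, unknown or untested is made for them only; others in the source may bear on it.

Measured compounds:
compound 1, `O=C(NCc1cc(Cl)ccc1-n1cnnn1)[C@@H]1[C@@H]2C[C@@H]2CN1C(=O)[C@H](O)c1ccccc1F`, 2.3 10^-6 cm/s
compound 2, `O=C(NCc1cc(Cl)ccc1-n1cnnn1)[C@@H]1C[C@@H]2C[C@@H]2N1C(=O)[C@H](O)c1ccccc1F`, 16 10^-6 cm/s
compound 3, `O=C(NCc1cc(Cl)ccc1-n1cnnn1)[C@@H]1[C@@H]2C[C@@H]2CN1C(=O)[C@H](O)c1ccccc1`, 2.2 10^-6 cm/s

The three measured compounds were examined in an ADME assay on Caco-2 cells (Homo sapiens) for permeability, read by LC-MS, in the apical to basolateral direction, with a stated time of 60 min, at pH 6.5; a lower number here means that the compound crosses the layer more slowly, a higher number that the compound crosses the layer faster. Compound 1 gives 2.3 10^-6 cm/s, and compound 3 gives 2.2 10^-6 cm/s. Compound 3 arises from compound 1 by the change (hydrogen in place of fluoro on an aromatic carbon), and this change moved the number a 1.0-fold lower number from compound 1 to compound 3 (0.02 log units; within the scatter). Compound 2 shares its atoms with compound 1 but has them joined differently; the difference between the two cores is not broken down here. In this assay compound 2 gives 16 10^-6 cm/s, the highest of the three numbers and beyond the scatter from both compound 1 and compound 3.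

Compound 4, `O=C(NCc1cc(Cl)ccc1-n1cnnn1)[C@@H]1C[C@@H]2C[C@@H]2N1C(=O)[C@H](O)c1ccccc1`, has not yet been measured in this assay. Within the data shown here, it arises from compound 2 by the change (hydrogen in place of fluoro on an aromatic carbon), the same change as the one from compound 1 to compound 3, made on the same place. Because the earlier step of a 1.0-fold lower number from compound 1 to compound 3 (0.02 log units; within the scatter) stayed within the scatter, the step from compound 2 to compound 4 is expected to be small as well, roughly a 1.1-fold lower number from compound 2 to compound 4 (0.03 log units; within the scatter), so that compound 4 is expected to stay close to the value of compound 2, 16 10^-6 cm/s. The estimate for compound 4 in this assay is therefore 15 10^-6 cm/s, with a range from 7 10^-6 cm/s to 30 10^-6 cm/s.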

Compound 4, apparent permeability: 8 10^-6 cm/s
For compound 4 the middle estimate is 1.9-fold (0.27 log units) above the measured one; the range from low to high includes it.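

In this assay, the exchange of 2-fluorophenyl for phenyl on the core of compound 2 gives a 2.0-fold lower number from compound 2 to compound 4 (0.30 log units; within the scatter), so on this core the step stays inside what repeated measurements would be expected to show. Set beside the same exchange on the other core, the new step gives no sign that the outcome depends on which of the two cores carries it: the same change on two cores in this assay, a 1.0-fold lower number (0.02 log units; within the scatter) from compound 1 to compound 3 and a 2.0-fold lower number (0.30 log units; within the scatter) from compound 2 to compound 4, 1.9-fold (0.28 log units) apart, within the scatter of two such steps. This shows that, for these two matched pairs, a small step seen on one core was followed by a step within the scatter on the other, but it does not show that the two steps are identical in size, that the same would hold on a third core, or why the exchange leaves the number so little moved.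

The compounds shown replace fluoro only with hydrogen, at one place on the ring, so it remains open whether a chloro, methoxy or amine group there would also leave the number within the scatter on both cores. Also open, on these data alone, is whether the same agreement between the cores would appear for a change elsewhere, such as an amine or a methoxy group in place of the hydroxyl group.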